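The compounds below may be only part of what the source reports. "The series", "measured", "known", "first", "only" and "open" are said of these compounds alone.

Compound 1 `CN/N=C/c1ccc2ccc(=O)oc2c1` is the stronger of the two measured compounds: in a functional assay for inhibition of serine protease 1 (Homo sapiens), tested at 1 mM (a higher number here means a stronger effect of the compound at the concentration tested, a lower number a weaker effect), compound 1 gives 97.6%, while compound 2 `O=c1ccc2ccc(/C=N/N=C/c3ccc4ccc(=O)oc4c3)cc2o1` gives 65.4%, a gap that lies beyond the usual scatter. Compound 3 `O=c1ccc2ccc(/C=N/c3ccccc3)cc2o1` has not yet been measured. It differs from compound 1 in one place: phenyl in place of methylamino on a double-bonded nitrogen. Among the measured compounds shown here, no measured pair isolates this change, so the size of its effect is unknown; the expected step of a number 22.6 percentage points lower from compound 1 to compound 3 (beyond the scatter) is a moderate drop beyond the scatter. Compound 3 is therefore estimated at 75%, with a likely range from 45% to 95%.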

Compound 3, a percentage reported as inhibition, at one concentration (the size of the read-out at that concentration, not a potency): 97.6%
Compound 3: middle estimate off by 22.6 percentage points, on the low side; the measured number lies above the stated range.
By their numbers in this assay, from the lowest: compound 2; then compounds 1 and 3 (each within the scatter of the next).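

Putting phenyl in place of methylamino on a double-bonded nitrogen gives no change at the digits printed from compound 1 to compound 3 (within the scatter) in this assay. At this one concentration, the position therefore accepts a six-membered aromatic ring of carbon only in place of a smaller group with no ring, even though the hydrogen-bond donor and acceptor of methylamino are gone. No measurement available gives a reason for this result. Still open, on these data alone, is whether a carboxylic acid or a longer carbon chain on this nitrogen would keep the read-out, and a read-out at one concentration cannot show whether potency differs.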